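A few compounds are considered here, and "the series" means these few. Any claim that something is new, unique, unknown or untested is made for them only; others in the source may bear on it.

Working notes on the series, where the group on the carbonyl carbon varies and the rest of the structure stays the same. In a physicochemical assay for lipophilicity, measured as octanol-water partition, at pH 7.4 (on this read-out lower numbers stand for lower lipophilicity and higher numbers for higher lipophilicity), compound 1 `Cc1ccc2[nH]c(C(=O)N[C@H]3CN(S(=O)(=O)c4ccccc4)C[C@@H]3C(=O)N[C@H]3CCCNC3)cc2c1` gives 1.3 and compound 2 `Cc1csc(C(=O)N[C@H]2CN(S(=O)(=O)c3ccccc3)C[C@@H]2C(=O)N[C@H]2CCCNC2)n1` gives 0.1. Compound 3 `O=C(N[C@H]1CN(S(=O)(=O)c2ccccc2)C[C@@H]1C(=O)N[C@H]1CCCNC1)c1cc(-c2ccccc2)on1` gives 1.3 and so stands level with compound 1, the two together at the top of the three numbers, with compound 2 well under them.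

Among the compounds with values here, the next change keeps the shared core and replaces only this group: a group of 12 heavy atoms (8 carbon, 2 nitrogen, 1 fluorine, 1 sulfur; one five-membered aromatic ring with 3 hetero atoms, one six-membered aromatic ring of carbon only) in place of a group of 11 heavy atoms (9 carbon, 1 nitrogen, 1 oxygen; one five-membered aromatic ring with 2 hetero atoms, one six-membered aromatic ring of carbon only), on a carbonyl carbon gives compound 4 `O=C(N[C@H]1CN(S(=O)(=O)c2ccccc2)C[C@@H]1C(=O)N[C@H]1CCCNC1)c1nnc(-c2ccc(F)cc2)s1` as the result.

All three measured steps were made at this same place. The move no change at the digits printed from compound 1 to compound 3 (within the scatter) stays within the scatter, while a number 1.20 log units lower from compound 1 to compound 2 (beyond the scatter) and a number 1.20 log units higher from compound 2 to compound 3 (beyond the scatter) are both large. Both large steps involve the 4-methyl-1,3-thiazol-2-yl group of compound 2, which has no six-membered aromatic ring of carbon only. The groups of compound 1 and compound 3 both have such a ring, and so does the group entering compound 4. The large steps are therefore a poor guide here, and the closer precedent is the flat step between compound 1 and compound 3. Within the data shown here, with only three measured compounds, this remains a thin basis.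

No step beyond the scatter is expected in this assay, and the estimated move is a number 0.10 log units lower from compound 3 to compound 4 (within the scatter) (slightly downward, if at all). For compound 4 the expected value is 1.2 (estimated range 0.7 to 1.7).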

Compound 4, distribution coefficient: 1
For compound 4 the middle estimate is 0.20 log units above the measured one; low and high end bracket the measured number.
By their numbers in this assay, from the lowest: compound 2; then compounds 4, 1 and 3 (each within the scatter of the next).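

In this assay, the place on the carbonyl carbon now holds a third group with a six-membered aromatic ring of carbon only, and this one has a five-membered aromatic ring with 3 hetero atoms and a fluorine; the readings are a number 0.30 log units lower from compound 3 to compound 4 (within the scatter) and a number 0.30 log units lower from compound 1 to compound 4 (within the scatter), so all three groups remain within the scatter of one another in these two steps. Compound 2, whose 4-methyl-1,3-thiazol-2-yl group has no such six-membered ring, stays apart, with a number 0.90 log units higher from compound 2 to compound 4 (beyond the scatter) as the new step, so the split seen among the first three compounds holds for all four shown here. No separate measurement bears on why the groups fall out this way.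

The change from compound 3 to compound 4 alters the five-membered ring and brings in the fluorine in one step, so the share of each stays unresolved. Also open, as far as these compounds go, is how a group without an aromatic ring, such as a carboxylic acid, an amine or a longer alkyl chain, would read on this carbonyl carbon.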